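The source may hold more compounds than are shown below. What is called first, only, known or untested is meant among the compounds shown, and "the series" means these compounds.

Compound 1 `COc1ccc(Nc2cc(C)oc(=O)c2)cc1` was tested in a functional assay on DU-145 cells (Homo sapiens) for cytotoxicity, read by MTT assay, with a stated time of 72 h; on this read-out lower numbers stand for an effect already at smaller amounts and higher numbers for an effect only at larger amounts of compound. In this assay compound 1 gives > 30 uM, which is a limit of the assay rather than a measured number. Compound 2 `O=c1cc(Nc2ccccc2)cc(-c2ccccc2)o1` carries a phenyl group in place of the methyl and has no methoxy group; in this assay compound 2 gives 0.098 uM. Compound 3 `COc1ccc(Nc2cc(/C=C/c3ccccc3)oc(=O)c2)cc1` differs from compound 1 in a single place: 2-phenylethenyl in place of methyl on an aromatic carbon. Among the measured compounds shown here, no two measured compounds differ in only one place, so the size of this step cannot be read from a measured pair. A large gain is nonetheless expected, because compound 2 gives 0.098 uM in this assay with a phenyl group in place of methyl, while compound 1 sits at the limit of > 30 uM in this assay, at which 1 of the 2 values shown sits. The estimate means a step of an at least 60-fold lower number from compound 1 to compound 3 (1.77 log units; beyond the scatter), expected to be well beyond the scatter. Compound 3 is expected to give 0.5 uM, with a range from 0.08 uM to 5 uM.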

Compound 3, concentration for half-maximal effect: 0.11 uM
Estimate against measurement, compound 3: 4.5-fold (0.66 log units) above; measured number inside the range.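

Replacing methyl with 2-phenylethenyl on the aromatic carbon next to the ring oxygen, with the rest of the molecule unchanged, gives an at least 270-fold lower number from compound 1 to compound 3 (2.43 log units; beyond the scatter), so this one place can by itself carry a large change in this assay. In this assay compound 1 gives > 30 uM, which is a limit of the assay and not a number. The true step may be larger still, because the starting point is only a limit: the limit of > 30 uM in this assay, at which 1 of the 3 values shown sits.

As far as these compounds go, it remains open which part of the 2-phenylethenyl group matters, the double bond or the aromatic ring. From the compounds shown here alone, how a saturated 2-phenylethyl chain, a shorter ethyl group or an amine would behave at this place also stays unknown.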